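A Fluorophenyl for a Dimethoxyphenyl on the Amine Chain

The compounds below may be only part of what the source reports. "The series", "measured", "known", "first", "only" and "open" are said of these compounds alone.

Of the compounds shown here, three sharing one core have been measured in a functional assay on K562 cells (Homo sapiens) for inhibition, read by sulforhodamine B assay, with a stated time of 48 h; a higher number here means a weaker inhibitor of growth, a lower number a stronger inhibitor of growth. For the measured compounds named here, compound 1 `Nc1cc(N)c2nc(-c3ccccc3)c(Sc3ccc(F)cc3)nc2c1` gives 39800 nM, and compound 2 `Nc1cc(N)c2nc(-c3ccccc3)c(Oc3ccc(F)cc3)nc2c1` gives 11000 nM; the only single-point step among them, a 3.6-fold lower number from compound 1 to compound 2 (0.56 log units; beyond the scatter), is a modest one. Compound 3 `COc1ccc(CNc2nc3cc(N)cc(N)c3nc2-c2ccccc2)cc1OC` gives 6030 nM, the lowest of the three numbers, within the scatter of compound 2 and beyond the scatter only against compound 1.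

Compound 4 `Nc1cc(N)c2nc(-c3ccccc3)c(NCc3ccc(F)cc3)nc2c1` differs from compound 3 in one place: 4-fluorophenyl in place of 3,4-dimethoxyphenyl on a saturated chain carbon bound to a nitrogen on an aromatic ring. Going by the values given here, no measured step bears on this change; the one step known alters the atom linking the aryl group to the core, not the substituents on that aryl group. With nothing in the data pointing either way, compound 4 is expected to sit close to compound 3, with a step of a 1.2-fold higher number from compound 3 to compound 4 (0.06 log units; within the scatter) that does not clearly exceed the scatter. Compound 4 is therefore estimated at 7000 nM in this assay, within a range from 2500 nM to 20000 nM.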

Compound 4, concentration for 50% growth inhibition: 4370 nM
The estimate for compound 4 lay 1.6-fold (0.20 log units) above the measured number, and the stated range covers the measured number.
By their numbers in this assay, from the lowest: compounds 4, 3 and 2 (each within the scatter of the next, the first and the last beyond it); then compound 1.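

On the saturated chain carbon bound to a nitrogen on an aromatic ring, 4-fluorophenyl in place of 3,4-dimethoxyphenyl gives, in this assay, a result that does not separate the two aryl groups (a 1.4-fold lower number from compound 3 to compound 4 (0.14 log units; within the scatter)). Compound 4 also allows the link on the aromatic carbon to be compared with the 4-fluorophenyl group kept: (4-fluorobenzyl)amino in place of 4-fluorophenoxy gives one step (a 2.5-fold lower number from compound 2 to compound 4 (0.40 log units; beyond the scatter)), and (4-fluorobenzyl)amino in place of (4-fluorophenyl)sulfanyl gives another (a 9.1-fold lower number from compound 1 to compound 4 (0.96 log units; beyond the scatter)). Among these compounds, both changes of link moved the number beyond the scatter, whereas the change on the aryl group did not.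

The compounds shown leave open whether a longer chain between the nitrogen and the aryl ring, or a carboxylic acid on that ring, would change the number beyond the scatter. No available measurement accounts for the differences among these compounds.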